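The source may hold more compounds than are shown below. What is called first, only, known or untested is meant among the compounds shown, and "the series" means these compounds.

Measured compounds in an ADME assay on PC-3 cells (Homo sapiens) for cytotoxicity, read by WST assay, tested at 100 uM; a higher number here means more inhibition at the concentration tested (going by the name of the read-out), a lower number less inhibition:
compound 1 `COC(=O)c1cccc(C(=O)N2CCCC(C(=O)Nc3ccc(Cl)cc3)C2)c1`: 0%
compound 2 `CS(=O)(=O)c1cccc(C(=O)N2CCCC(C(=O)Nc3ccc(Cl)cc3)C2)c1`: 2%

Compound 2 and compound 1 sit together at the floor of the read-out: the step of a number 2 percentage points higher from compound 1 to compound 2 (within the scatter) is within the scatter, so neither stands apart from the other, and compound 2 is simply one of two compounds showing essentially no inhibition.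

Compound 3 `O=C(Nc1ccc(Cl)cc1)C1CCCN(C(=O)c2cccc(-c3cnco3)c2)C1` is not yet measured. It differs from compound 2 by 1,3-oxazol-5-yl in place of methylsulfonyl on an aromatic carbon. For the measured compounds named here, only one measured step bears on this change, the exchange at the same aromatic carbon, a number 2 percentage points higher from compound 1 to compound 2 (within the scatter), which left the read-out flat. With both measured compounds near zero and no step beyond the scatter in the set, no movement beyond the scatter is expected, a number 1 percentage points higher from compound 2 to compound 3 (within the scatter). The estimate for compound 3 in this assay is 3%, with a range from -8% to 15%.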

Compound 3, a percentage reported as inhibition, at one concentration (the size of the read-out at that concentration, not a potency): 0%
Beside the measured number, compound 3's estimate is 3 percentage points above it, and the stated range covers the measured number.
By their numbers in this assay, from the lowest: compounds 1, 3 and 2 (each within the scatter of the next).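

In this assay, the 1,3-oxazol-5-yl group on this aromatic carbon, meta to a large group, gives no reading that stands apart: a number 2 percentage points lower from compound 2 to compound 3 (within the scatter), and no change at the digits printed from compound 1 to compound 3 (within the scatter). The flat picture therefore extends from two acyclic groups, methylsulfonyl and methoxycarbonyl, to a five-membered aromatic ring with 2 hetero atoms at the same place. No supporting measurement bears on why this exchange leaves the read-out flat.

Going by these compounds, all three compounds sit near the floor of this read-out, so it remains unknown whether any exchange at this carbon can raise inhibition at the concentration tested. On these data alone, whether an amine or a carboxylic acid at this carbon, or a change elsewhere on the shared core, would move the number also remains open.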